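A Hydroxypropyl Chain Replaces the Pyrimidinyl Group

The compounds below may be only part of what the source reports. "The series", "measured", "known", "first", "only" and "open" are said of these compounds alone.

Measured compounds in an assay on HEK293 cells for agonist activity at transient receptor potential cation channel subfamily M member 8 (Homo sapiens), read by fluorescence and calcium flux, with a stated time of 15 min; a higher number here means that more compound is needed for the effect, a lower number that less compound is needed:
- compound 1 `Cc1ccc(OCC(=O)N(Cc2cccs2)CC(C)C)cc1` gives 900 nM
- compound 2 `Cc1ccc(OCC(=O)N(Cc2cccs2)c2cnn(C)c2)cc1` gives 63000 nM
- compound 3 `Cc1ccc(OCC(=O)N(Cc2cccs2)c2ncccn2)cc1` gives 3700 nM

Compound 3 holds the second highest number of the three: a 4.1-fold higher number from compound 1 to compound 3 (0.61 log units; beyond the scatter), while a 17-fold lower number from compound 2 to compound 3 (1.23 log units; beyond the scatter). Compound 4 `Cc1ccc(OCC(=O)N(CCCO)Cc2cccs2)cc1` differs from compound 3 by 3-hydroxypropyl in place of pyrimidin-2-yl on an amide-type nitrogen.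

Within the data shown here, no measured step exchanges a ring for a chain bearing a hydroxyl, so the change has no direct precedent. The nearest evidence is the isobutyl chain of compound 1, from which replacement by an aromatic group raised the number each time: a 4.1-fold higher number from compound 1 to compound 3 (0.61 log units; beyond the scatter) and a 70-fold higher number from compound 1 to compound 2 (1.85 log units; beyond the scatter). Going back from the pyrimidin-2-yl ring to a chain is therefore expected to move the number downward, though the hydroxyl group carries an uncertainty that the measured compounds cannot resolve. Compound 4 is accordingly expected to give about 1500 nM in this assay. For compound 4 the expected range runs from 400 nM to 8000 nM. The estimate for compound 4 thus implies a 2.5-fold lower number from compound 3 to compound 4 (0.39 log units; beyond the scatter).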

Compound 4, half-maximal effective concentration: 3000 nM
The estimate for compound 4 lay 2.0-fold (0.30 log units) below the measured number, and the stated range covers the measured number.
By their numbers in this assay, from the lowest: compound 1; then compounds 4 and 3 (each within the scatter of the next); then compound 2.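

At the amide-type nitrogen, a chain without a ring can take the place of an aromatic ring with no readable change: in this assay, 3-hydroxypropyl in place of pyrimidin-2-yl gives a 1.2-fold lower number from compound 3 to compound 4 (0.09 log units; within the scatter). The same chain in place of 1-methyl-1H-pyrazol-4-yl gives a 21-fold lower number from compound 2 to compound 4 (1.32 log units; beyond the scatter), so the high number of compound 2 is not shared by this chain. Having a chain here is not enough to reach the number of compound 1, however, as the isobutyl chain and the 3-hydroxypropyl chain are separated by a 3.3-fold higher number from compound 1 to compound 4 (0.52 log units; beyond the scatter).

No measured evidence accounts for any of these steps. The compounds shown leave open how a plain propyl chain, a 3-aminopropyl chain, a carboxylic acid on the chain or a longer hydroxyalkyl chain would read at this nitrogen.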